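The source may hold more compounds than are shown below. What is called first, only, known or untested is meant among the compounds shown, and "the series" means these compounds.

Working notes on the series. Two compounds have numbers in a functional assay on SK-MEL-28 cells (Homo sapiens) for inhibition, read by sulforhodamine B assay, with a stated time of 48 h; on this read-out higher numbers stand for weaker inhibition of growth and lower numbers for stronger inhibition of growth. Among the compounds with values here, compound 2 `COc1cc2cc(Oc3ccc(NC(=O)Nc4ccc(Cl)c(C(F)(F)F)c4)cc3)c(C)nc2cc1OC` stands lowest of the two, giving 5450 nM; compound 1 `COc1cc2cc(Oc3ccc(NC(=O)Nc4cccc(C(F)(F)F)c4)cc3)c(C)nc2cc1OC` gives 8370 nM, and the single measured step, a 1.5-fold lower number from compound 1 to compound 2 (0.19 log units; within the scatter), lies within the scatter. Compound 3 `COc1cc2cc(Oc3ccc(NC(=O)Nc4ccc(Cl)c(Cl)c4)cc3)c(C)nc2cc1OC` differs from compound 2 by chloro in place of trifluoromethyl on an aromatic carbon. No measured step exchanges a trifluoromethyl for a chloro, and the one step shown, a chloro in place of hydrogen, moved nothing beyond the scatter, so no step beyond the scatter is expected in this assay. Compound 3 is therefore estimated at 6000 nM, range 2500 nM to 15000 nM, which means an expected step of a 1.1-fold higher number from compound 2 to compound 3 (0.04 log units; within the scatter).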

Compound 3, concentration for total growth inhibition: 14700 nM
Compound 3: middle estimate off by 2.5-fold (0.39 log units), on the low side, within the range that was stated.
By their numbers in this assay, from the lowest: compounds 2, 1 and 3 (each within the scatter of the next, the first and the last beyond it).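

In this assay, within the data shown here, trifluoromethyl to chloro at the position ortho to a chloro group gives a 2.7-fold higher number from compound 2 to compound 3 (0.43 log units; beyond the scatter), the first step beyond the scatter, so this position does respond to a change of group. By contrast, a 1.8-fold higher number from compound 1 to compound 3 (0.24 log units; within the scatter) stays within the scatter, so the 3,4-dichlorophenyl and 3-(trifluoromethyl)phenyl ureas are not separated here. No evidence bears on what lies behind the step.

Open, going by these compounds, is how a methyl, methoxy or nitrile would read at this same position with the neighbouring chloro kept.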